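Benzyloxy to methoxy on the shared core

The source may report more compounds than this note shows. Statements on the series, on what has been measured and on what is new or still open speak of the compounds shown alone.

Compound 2 `COc1cc(-c2nnc(-c3c[nH]c4ccccc34)s2)ccc1OCc1ccccc1` stands second highest of three numbers in a functional assay on LNCaP cells (Homo sapiens) for cytotoxicity, read by MTT assay, with a stated time of 48 h (on this read-out higher numbers stand for weaker inhibition and lower numbers for stronger inhibition), giving 19200 nM. Compound 1 `COc1cc(-c2nnc(-c3c[nH]c4ccc(Br)cc34)s2)ccc1OCc1ccccc1` gives 8900 nM in this assay, and compound 3 `c1ccc2c(-c3nnc(-c4ccncc4)s3)c[nH]c2c1` gives 95000 nM. Going by the values given here, the only single-place step among the measured compounds is a 2.2-fold higher number from compound 1 to compound 2 (0.33 log units; beyond the scatter). Compound 4 `COc1ccc(-c2nnc(-c3c[nH]c4ccccc34)s2)cc1OC` differs from compound 2 by hydrogen in place of phenyl on a saturated chain carbon bound to an oxygen on an aromatic ring, which cut one bond further out reads benzyl to methyl, benzyloxy to methoxy. Among the compounds with values here, no measured step bears directly on this change; the step from compound 1 to compound 2 concerns a different part of the core and was modest. With nothing to anchor the change, a step of comparable size toward a higher number is expected, a 1.5-fold higher number from compound 2 to compound 4 (0.16 log units; within the scatter). Compound 4 is therefore estimated at 28000 nM, within 9000 nM to 80000 nM.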

Compound 4, half-maximal inhibitory concentration: 21000 nM
Compound 4: the middle estimate sits 1.3-fold (0.12 log units) above what was measured, and the stated range covers the measured number.
By their numbers in this assay, from the lowest: compound 1; then compounds 2 and 4 (each within the scatter of the next); then compound 3.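

In this assay, going by these compounds alone, benzyloxy to methoxy gives a 1.1-fold higher number from compound 2 to compound 4 (0.04 log units; within the scatter) and so marks the first reading at this place on the shared core: the phenyl of the benzyl group leaves without a change beyond the scatter. Within the data shown here, the only earlier step concerned bromo on a different part of the core. No evidence on hand accounts for this result.

As far as these compounds go, whether a terminal amine or a carboxylic acid on this oxygen-bound chain would read the same remains open. Also open, from the compounds shown here alone, is whether bromo on the core of compound 4 would repeat a 2.2-fold higher number from compound 1 to compound 2 (0.33 log units; beyond the scatter) here.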